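Methoxy in place of methyl on a dimethyl-bearing core

A few compounds are considered here, and "the series" means these few. Any claim that something is new, unique, unknown or untested is made for them only; others in the source may bear on it.

Compound 1, `O=C1CCCC2=C1C(c1ccc(Cl)cc1)C=C(c1ccccc1)N2`, gives 8.21% in an assay on isolated protein for inhibition of glucose-6-phosphatase catalytic subunit 1 (Homo sapiens), read by inositol phosphate accumulation, with a stated time of 30 min, tested at 100 uM; on this read-out lower numbers stand for less inhibition and higher numbers for more inhibition at the one concentration tested (going by the name of the read-out).
Compound 2, `COc1ccc(C2C=C(c3ccccc3)NC3=C2C(=O)CCC3)cc1`, gives 17.3% in this assay.
Compound 3, `Cc1ccc(C2=CC(c3ccccc3)C3=C(CC(C)(C)CC3=O)N2)cc1`, is reported in this assay as "not active" (no number reported), with no number given.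

The account follows the step from compound 3 to compound 4, `COc1ccc(C2=CC(c3ccccc3)C3=C(CC(C)(C)CC3=O)N2)cc1`. Compound 3 stands apart from the two compounds with numbers: in this assay compound 3 is reported as "not active" (no number reported), so no number can be set beside those of compound 1 and compound 2. The change is methoxy in place of methyl on an aromatic carbon. For the measured compounds named here, one measured step bears on it loosely: a number 9.1 percentage points higher from compound 1 to compound 2 (within the scatter), where a methoxy group likewise enters on an aromatic carbon, though in place of chloro and on a core without the two methyl groups. That step stayed within the scatter. Going by the values given here, with compound 3 giving no number and the one related step small, a step in this assay no larger than the scatter is expected, in no particular direction. Compound 4 is therefore expected to give about 10% in this assay, within a range of 0% to 25%.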

Compound 4, a percentage reported as inhibition, at one concentration (the size of the read-out at that concentration, not a potency): 8.34%
The estimate for compound 4 lay 1.7 percentage points above the measured number; measured number inside the range.
By their numbers in this assay, from the lowest: compounds 1, 4 and 2 (each within the scatter of the next).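

For the compounds shown here, compound 3 has no number in this assay, while compound 4 gives 8.34% here, so no step between them can be read. Nothing measured here offers an explanation for this result. The compounds shown leave open whether 4-methylphenyl to 4-methoxyphenyl alters inhibition at all.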